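Swapping the five-membered ring on the hydrazone carbon

This account rests on a few compounds, and the source may have more. Where it says the series, first, only, none or still open, it means among the compounds named here.

Compound 1, `CC1=CC[C@H](C(C)(C)NC(=S)N/N=C/c2ccco2)CC1`, gives 9800 nM in a functional assay on 786-0 cells (Homo sapiens) for inhibition, read by sulforhodamine B assay, with a stated time of 48 h; on this read-out lower numbers stand for stronger inhibition of growth and higher numbers for weaker inhibition of growth.
Compound 2, `CC1=CC[C@H](C(C)(C)NC(=S)N/N=C/c2ccc[nH]2)CC1`, reaches only a limit of this assay, > 100000 nM.

In this assay compound 1 therefore stands at a measured number, while compound 2 stands at the limit of > 100000 nM in this assay, at which 1 of the 2 values shown sits, so only a bound is known for compound 2. For the measured compounds named here, the one measured step, an at least 10-fold higher number from compound 1 to compound 2 (1.00 log units; beyond the scatter), is the only one bearing on what follows. Compound 3, `CC1=CC[C@H](C(C)(C)NC(=S)N/N=C/c2cccs2)CC1`, differs from compound 2 by thiophen-2-yl in place of 1H-pyrrol-2-yl on a carbon with a double bond to nitrogen; the entering ring carries no hydrogen-bond donor and one hydrogen-bond acceptor, which makes it resemble the ring of compound 1 more than that of compound 2. Since the step from compound 1 to compound 2 was at least modest, the reverse-leaning change is expected to bring compound 3 back toward the number of compound 1, giving an estimated at least 6.6-fold lower number from compound 2 to compound 3 (0.82 log units; beyond the scatter). Compound 3 is thus expected to give 15000 nM, within a range from 4000 nM to 80000 nM.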

Compound 3, concentration for total growth inhibition: 26700 nM
For compound 3 the middle estimate is 1.8-fold (0.25 log units) below the measured one; the measured number falls inside the stated range.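

With thiophen-2-yl on the carbon with a double bond to nitrogen, activity in this assay returns to a measurable level, giving an at least 3.7-fold lower number from compound 2 to compound 3 (0.57 log units; beyond the scatter). Going by these compounds, this step is only a bound, so the size of the change from 1H-pyrrol-2-yl remains unknown. The return is also incomplete. Replacing furan-2-yl with thiophen-2-yl gives a 2.7-fold higher number from compound 1 to compound 3 (0.44 log units; beyond the scatter), which shows that the two rings without the hydrogen-bond donor of 1H-pyrrol-2-yl are not interchangeable at this position.

How far compound 2 really lies from the other two stays open, since its value is a limit of the assay: the limit of > 100000 nM in this assay, at which 1 of the 3 values shown sits. The compounds shown also leave open how a six-membered ring such as phenyl or pyridin-2-yl, or a methyl group on the furan ring, would fare at this position.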